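This account rests on a few compounds, and the source may have more. Where it says the series, first, only, none or still open, it means among the compounds named here.

Measured so far:
compound 1 `CN(C)CCCOc1ccc(CN(C)c2nc3ccc(Oc4ccc(C(F)(F)F)cc4)cc3s2)cc1`, 46000 nM
compound 2 `CN(Cc1ccc(OCCCNC(=N)N)cc1)c1nc2ccc(Oc3ccc(C#N)cc3)cc2s1`, 143000 nM

Both were tested in an assay on SH-SY5Y cells for inhibition of Voltage-dependent N-type calcium channel subunit alpha-1B (Homo sapiens), read by FLIPR and calcium flux, with stated times of 600 s and 300 s, in the presence of a further agent that is not named here; on this read-out lower numbers stand for stronger inhibition and higher numbers for weaker inhibition. Compound 2 gives the highest of the two numbers; compound 1 sits a clear step lower, beyond the usual scatter. Compound 3 `CN(C)CCCOc1ccc(CN(C)c2nc3ccc(Oc4ccc(C#N)cc4)cc3s2)cc1` has not been measured. It differs from compound 2 in one place: a group of 3 heavy atoms (2 carbon, 1 nitrogen; no ring) in place of a group of 4 heavy atoms (1 carbon, 3 nitrogen; no ring), on a saturated chain carbon, three bonds along the chain from an oxygen on an aromatic ring. Going by the values given here, no measured pair isolates this change, so the expected size of the step in this assay is uncertain, but since compound 1 carries the dimethylamino chain and gives 46000 nM, a modest move toward lower numbers is expected, a 1.8-fold lower number from compound 2 to compound 3 (0.25 log units; within the scatter). Compound 3 is estimated at 80000 nM, within 30000 nM to 200000 nM.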

Compound 3, half-maximal inhibitory concentration: 69000 nM
The estimate for compound 3 lay 1.2-fold (0.06 log units) above the measured number; measured number inside the range.
By their numbers in this assay, from the lowest: compounds 1 and 3 (each within the scatter of the next); then compound 2.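

In this assay, with cyano kept on the aromatic carbon, dimethylamino in place of the group of 4 heavy atoms (1 carbon, 3 nitrogen) gives a 2.1-fold lower number from compound 2 to compound 3 (0.32 log units; beyond the scatter), so a change on this saturated chain carbon can shift the number, though only modestly. Cyano in place of trifluoromethyl gives a 1.5-fold higher number from compound 1 to compound 3 (0.18 log units; within the scatter), so this pair does not separate those two groups. Nothing measured here gives a reason for either step.

As far as these compounds go, whether a primary amine or a carboxylic acid on that chain carbon would give a clearly lower number remains open. So does the effect of a longer chain.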